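Bromo in place of hydrogen on a benzimidazole-bearing amide

The source may report more compounds than this note shows. Statements on the series, on what has been measured and on what is new or still open speak of the compounds shown alone.

Measured compounds:
- compound 1 `Cc1ccc2nc(-c3cccc(NC(=O)CCc4ccccc4)c3)[nH]c2c1`: 26600 nM
- compound 2 `O=C(CCc1ccccc1)Nc1cccc(-c2nc3ccccc3[nH]2)c1`: 68000 nM

In an assay on cells for inhibition of matrix metalloproteinase-9 (Homo sapiens), read by fluorescence, with stated times of 15 min and 4 h (on this read-out higher numbers stand for weaker inhibition and lower numbers for stronger inhibition), compound 2 gives 68000 nM, the higher of the two numbers recorded; its nearest neighbour is compound 1, which in this assay gives 26600 nM. Among the measured compounds shown here, the single measured step, a 2.6-fold higher number from compound 1 to compound 2 (0.41 log units; beyond the scatter), arises from hydrogen in place of methyl on an aromatic carbon and is modest but beyond the scatter.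

Compound 3 `O=C(CCc1ccccc1)Nc1cccc(-c2nc3ccc(Br)cc3[nH]2)c1` differs from compound 2 by bromo in place of hydrogen on an aromatic carbon. For the measured compounds named here, the only step that bears on this change is the one from compound 1 to compound 2, where a small group on the same fused system of the shared core went with a lower number. A step of similar modest size in the opposite direction is therefore expected for compound 3, giving a 1.9-fold lower number from compound 2 to compound 3 (0.29 log units; within the scatter) in this assay. Compound 3 is estimated at 35000 nM, with a range of 12000 nM to 120000 nM.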

Compound 3, half-maximal inhibitory concentration: 14500 nM
Estimate against measurement, compound 3: 2.4-fold (0.38 log units) above, and the stated range covers the measured number.
By their numbers in this assay, from the lowest: compounds 3 and 1 (each within the scatter of the next); then compound 2.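

Placing bromo on this aromatic carbon gives a 4.7-fold lower number from compound 2 to compound 3 (0.67 log units; beyond the scatter) in this assay, so hydrogen can now be set against two different substituents at this carbon, and each goes with a lower number than hydrogen. The two substituents themselves are not separated by these data: a 1.8-fold lower number from compound 1 to compound 3 (0.26 log units; within the scatter) stays within the scatter, so bromo and methyl cannot be ranked here. Nothing in the data accompanying these numbers explains why either substituent differs from hydrogen.

From the compounds shown here alone, whether other groups on this carbon, such as chloro, methoxy, an amine or a carboxylic acid, would go with numbers like those of compound 1 and compound 3 or like that of compound 2 remains open. Going by these compounds, it is also open whether bromo would give a step of similar size with a longer chain on the amide carbonyl.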